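This account rests on a few compounds, and the source may have more. Where it says the series, first, only, none or still open, it means among the compounds named here.

Compound 1, `O=C(CSc1nc(Nc2ccccc2)c2ccccc2n1)Nc1cccc(Cl)c1`, gives 12600 nM in a functional assay on PC-3 cells (Homo sapiens) for inhibition, read by MTT assay, with a stated time of 72 h; a lower number here means a stronger inhibitor, a higher number a weaker inhibitor.
Compound 2, `O=C(CSc1nc(Nc2ccccc2)c2ccccc2n1)Nc1ccc(F)c(Cl)c1`, gives 15500 nM in this assay.
Compound 3, `C=CC(=O)Nc1cccc(NC(=O)CSc2nc(Nc3cccc(Cl)c3)c3ccccc3n2)c1`, gives 12300 nM in this assay.

Going by the values given here, of these three numbers, the one for compound 3 is the lowest, yet its gaps to compound 1 and to compound 2 are both within the scatter, so the three compounds cannot be told apart on these data.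

Compound 4, `C=CC(=O)Nc1cccc(NC(=O)CSc2nc(Nc3ccc(Cl)c(Cl)c3)c3ccccc3n2)c1`, is not yet measured. It differs from compound 3 in one place: chloro in place of hydrogen on an aromatic carbon.

Among the compounds with values here, only one measured step bears on such a change: a 1.2-fold higher number from compound 1 to compound 2 (0.09 log units; within the scatter). That step also added a halogen to an aromatic carbon, though on a different ring of the shared core, and it stayed within the scatter. With nothing else to go on, the expectation for compound 4 is no step beyond the scatter in this assay, that is a 1.0-fold lower number from compound 3 to compound 4 (0.01 log units; within the scatter). Compound 4 is therefore estimated at 12000 nM, with a likely range from 5000 nM to 30000 nM.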

Compound 4, half-maximal inhibitory concentration: 27600 nM
Compound 4: the middle estimate sits 2.3-fold (0.36 log units) below what was measured; the measured number falls inside the stated range.
By their numbers in this assay, from the lowest: compounds 3, 1, 2 and 4 (each within the scatter of the next, the first and the last beyond it).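

Adding a second chloro to the 3-chlorophenyl group, para to a large group, gives a 2.2-fold higher number from compound 3 to compound 4 (0.35 log units; beyond the scatter) in this assay, so this position does respond to the change, though only modestly. The earlier halogen step, a 1.2-fold higher number from compound 1 to compound 2 (0.09 log units; within the scatter), placed fluoro on a different ring and stayed within the scatter, so this is the first single-place change among these compounds to go beyond it, and it moves towards weaker inhibition. Nothing available here explains why this chloro raises the number.

Still open, from the compounds shown here alone, is whether the loss belongs to chloro itself or would also follow a fluoro, a methoxy group or an amine at this position. Going by these compounds, it is also open whether the same chloro would have a similar effect on a compound without the acrylamide group.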